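The compounds below may be only part of what the source reports. "The series", "measured", "known", "first", "only" and "open" are said of these compounds alone.

Compound 1 `CC(C)COc1cccc(-c2ccc(C(=O)N(Cc3cccc(OCCCCCC(=O)O)c3)C(C)C)cc2)c1` in an ADME assay on HEK293 cells (Homo sapiens) for cytotoxicity, read by CellTiter-Glo and resazurin assay, with a stated time of 72 h (on this read-out higher numbers stand for an effect only at larger amounts of compound and lower numbers for an effect already at smaller amounts), gives > 26000 nM, which is a limit of the assay rather than a number.
Compound 2 `CCOC(=O)CCCCCOc1cccc(CN(C(=O)c2ccc(-c3cccc(OCC(C)C)c3)cc2)C(C)C)c1` in this assay gives > 26000 nM, again a limit.
Compound 3 `CCOC(=O)CCCCCOc1cccc(CN(C(=O)c2ccc(-c3cccc(OCc4ccccc4)c3)cc2)C(C)C)c1` in this assay gives > 26000 nM, also a limit.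

Compound 2 therefore stands where every measured compound stands, at the limit itself: the limit of > 26000 nM in this assay, at which 3 of the 3 values shown sit. No compound among the three has shown an effect within the tested range, so no ordering among them can be drawn.

Compound 4 `CCOC(=O)CCCCCOc1cccc(CN(C(=O)c2ccc(-c3cc(OC)ccc3F)cc2)C(C)C)c1` differs from compound 2 in one place: 2-fluoro-5-methoxyphenyl in place of 3-(isobutoxy)phenyl on an aromatic carbon. Going by the values given here, two measured steps bear on this change. The step that the two limits leave unreadable from compound 1 to compound 2 alters the ester end of the chain, and the step that the two limits leave unreadable from compound 2 to compound 3 alters the group on the pendant ring, the same region that changes in compound 4. Both steps run from one limit to another limit, so their size cannot be read in either direction. Nothing in these numbers points to a step beyond the scatter for compound 4. The expected step from compound 2 to compound 4 is accordingly a step that the limit leaves unreadable from compound 2 to compound 4, with a wide range. For compound 4 in this assay the estimate is 30000 nM, spanning from 12000 nM to 80000 nM, and most likely the assay again reports only a limit.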

Compound 4, half-maximal effective concentration: > 26000 nM
Compound 4: no number, only a limit; the forecaster's own chance of this, stated with the estimate: 80%; the middle value is on the limit's open side.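

In this assay compound 4 gives > 26000 nM, again a limit of the assay rather than a number. No step from compound 2 to compound 4 can therefore be read, since both sit at the same limit: the limit of > 26000 nM in this assay, at which 4 of the 4 values shown sit.

The compounds shown leave open at what concentration any of them would affect these cells, and whether any of these structural changes alters that concentration.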